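The source may hold more compounds than are shown below. What is called first, only, known or untested is meant among the compounds shown, and "the series" means these compounds.

Compound 3 `O=C(Nc1cccc(/C=C/C(=O)c2nc3ccccc3[nH]2)c1)c1cc(Cl)cc(Cl)c1` gives the smallest of the three numbers in a functional assay on 143B cells (Homo sapiens) for antiproliferative activity, read by MTT assay, with a stated time of 48 h (a lower number here means a stronger inhibitor, a higher number a weaker inhibitor), at 3660 nM, but neither neighbour is clearly separated from it: compound 2 `Cc1cccc(C(=O)Nc2cccc(/C=C/C(=O)c3nc4ccccc4[nH]3)c2)c1` gives 4880 nM and compound 1 `O=C(Nc1cccc(/C=C/C(=O)c2nc3ccccc3[nH]2)c1)c1ccc(Br)cc1` gives 7310 nM, with a 2.0-fold lower number from compound 1 to compound 3 (0.30 log units; within the scatter) and a 1.3-fold lower number from compound 2 to compound 3 (0.12 log units; within the scatter) both inside the scatter, as is a 1.5-fold lower number from compound 1 to compound 2 (0.18 log units; within the scatter). Compound 4 `O=C(/C=C/c1cccc(NS(=O)(=O)c2ccccc2Cl)c1)c1nc2ccccc2[nH]1` differs from compound 3 by (2-chlorophenyl)sulfonyl in place of (3,5-dichlorophenyl)carbonyl on a nitrogen on an aromatic ring. Within the data shown here, none of the measured steps exchanges the carbonyl for a sulfonyl; they only vary the substituents on the phenyl ring, and all were small. Nothing here therefore points to a change beyond the scatter, and compound 4 is expected near compound 3 with a 1.1-fold higher number from compound 3 to compound 4 (0.04 log units; within the scatter), estimated at 4000 nM within 1500 nM to 11000 nM.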

Compound 4, half-maximal inhibitory concentration: 4790 nM
Compound 4: middle estimate off by 1.2-fold (0.08 log units), on the low side; the measured number falls inside the stated range.
By their numbers in this assay, from the lowest: compounds 3, 4, 2 and 1 (each within the scatter of the next).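

In this assay, the change from a carbonyl to a sulfonyl link on this nitrogen stays within the scatter against all three earlier compounds, with a 1.3-fold higher number from compound 3 to compound 4 (0.12 log units; within the scatter) and a 1.0-fold lower number from compound 2 to compound 4 (0.01 log units; within the scatter) and a 1.5-fold lower number from compound 1 to compound 4 (0.18 log units; within the scatter) as the steps. The four compounds therefore show that this position can carry (2-chlorophenyl)sulfonyl without a clear departure from the carbonyl series, although the ring substituents change together with the link. No available evidence bears on this result. From the compounds shown here alone, it remains open whether a free amine at this nitrogen, or a carboxylic acid on the phenyl ring, would move the number beyond the scatter.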